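Working notes: side-chain change at the hydroxy carbon

This account rests on a few compounds, and the source may have more. Where it says the series, first, only, none or still open, it means among the compounds named here.

Measured in an ADME assay on Caco-2 cells (Homo sapiens) for permeability, read by LC-MS, in the apical to basolateral direction, with a stated time of 60 min, at pH 6.5; on this read-out higher numbers stand for higher permeability and lower numbers for lower permeability:
- compound 1 `CC(C)(C)C[C@@H](O)C(=O)N1N=CC[C@H]1C(=O)NCc1cc(Cl)ccc1-n1cnnn1`: 24 10^-6 cm/s
- compound 2 `CC(C)CC[C@@H](O)C(=O)N1N=CC[C@H]1C(=O)NCc1cc(Cl)ccc1-n1cnnn1`: 29 10^-6 cm/s

Going by the values given here, neither number stands clear of the other, so compound 2 sits level with the only other measured compound. The next structure is compound 3 `CC(C)(C)[C@@H](O)C(=O)N1N=CC[C@H]1C(=O)NCc1cc(Cl)ccc1-n1cnnn1`, with tert-butyl in place of isopentyl on a saturated chain carbon bound to a carbonyl carbon and an oxygen on a saturated carbon. Among the compounds with values here, the one measured step that bears on this, at a carbon two bonds along the chain, is a 1.2-fold higher number from compound 1 to compound 2 (0.08 log units; within the scatter). Within the data shown here, with only that step as a guide, no change beyond the scatter is expected in this assay. The expected step is a 1.3-fold lower number from compound 2 to compound 3 (0.10 log units; within the scatter). For compound 3 the estimate is 23 10^-6 cm/s, with a range of 11 10^-6 cm/s to 45 10^-6 cm/s.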

Compound 3, apparent permeability: 15 10^-6 cm/s
Beside the measured number, compound 3's estimate is 1.5-fold (0.19 log units) above it; low and high end bracket the measured number.
By their numbers in this assay, from the lowest: compounds 3, 1 and 2 (each within the scatter of the next).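

In this assay, tert-butyl on a saturated chain carbon bound to a carbonyl carbon and an oxygen on a saturated carbon gives a 1.9-fold lower number from compound 2 to compound 3 (0.29 log units; within the scatter) in place of isopentyl, and a 1.6-fold lower number from compound 1 to compound 3 (0.20 log units; within the scatter) in place of neopentyl. Both steps lie within the scatter, so this position now shows three chains, including the shortest so far, that cannot be told apart on this read-out. No measurement on hand offers an explanation for these numbers.

Going by these compounds, whether an amine, a carboxylic acid or a longer chain at this position would give a step beyond the scatter remains open.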